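The source may report more compounds than this note shows. Statements on the series, on what has been measured and on what is new or still open speak of the compounds shown alone.

Compound 1 (`CCCC(=O)OCSc1ccccc1C(=O)NCCC(N)=O`) reads > 100 uM in an ADME assay on CEM-SS cells (Homo sapiens) for cytotoxicity, read by XTT assay, with a stated time of 6 days (a lower number here means that less compound is tolerated, a higher number that more compound is tolerated), which is a limit of the assay and not a number. Compound 3 (`CCCC(=O)OCSc1ccccc1C(=O)NCC(=O)N(C)C`) gives 38.3 uM and compound 2 (`CCCC(=O)OCSc1ccccc1C(=O)N[C@@H]1CCC[C@H]1C(N)=O`) gives 43.7 uM, so the two stand level: a 1.1-fold lower number from compound 2 to compound 3 (0.06 log units; within the scatter). Compound 4 (`CCCC(=O)OCSc1ccccc1C(=O)NCC(=O)NC(C)C`) has isopropylamino in place of dimethylamino on a carbonyl carbon. Among the measured compounds shown here, no measured step makes this exact change. The closest is an at least 2.6-fold lower number from compound 1 to compound 3 (0.41 log units; beyond the scatter), a step that starts from a limit and so gives only a bound. Going by a 1.1-fold lower number from compound 2 to compound 3 (0.06 log units; within the scatter), no step beyond the scatter is expected in this assay, and no direction is favoured. The expected step is a 1.0-fold higher number from compound 3 to compound 4 (0.02 log units; within the scatter), within the scatter. For compound 4 the estimated value is 40 uM, with an expected range of 18 uM to 90 uM.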

Compound 4, half-maximal toxic concentration: 92 uM
The estimate for compound 4 lay 2.3-fold (0.36 log units) below the measured number, and the stated range ends below it.
By their numbers in this assay, from the lowest: compounds 3 and 2 (each within the scatter of the next); then compound 4. At a limit, above all of these: compound 1.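

In this assay, isopropylamino in place of dimethylamino on a carbonyl carbon gives a modest step: a 2.4-fold higher number from compound 3 to compound 4 (0.38 log units; beyond the scatter). The shift also holds against the other low compound, with a 2.1-fold higher number from compound 2 to compound 4 (0.32 log units; beyond the scatter). Compound 1 is a limit and not a number: the limit of > 100 uM in this assay, at which 1 of the 4 values shown sits. The step that starts from this limit gives only a bound and cannot be read as a change: an at least 1.0-fold lower number from compound 1 to compound 4 (0.03 log units; that floor lies within the scatter).

The change adds a donor and a carbon at once, and the compounds shown do not separate the two. Methylamino or tert-butylamino on the same carbonyl carbon would be needed to tell them apart.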